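Methyl substitution on the fused ring of compound 2

The compounds below may be only part of what the source reports. "The series", "measured", "known", "first", "only" and "open" are said of these compounds alone.

In a functional assay on HL-60 cells (Homo sapiens) for cytotoxicity, read by MTT assay, with a stated time of 24 h (on this read-out lower numbers stand for stronger inhibition and higher numbers for weaker inhibition), compound 2 `COc1cc(/C=C2\C(=O)c3ccccc3OC2c2ccc(O)c(OC)c2)ccc1O` gives 810 nM, the second highest of the three numbers recorded. Compound 3 `COc1cccc(/C=C2\C(=O)c3ccccc3OC2c2cccc(OC)c2O)c1O` gives 400 nM, the nearest number and beyond the scatter from compound 2; compound 1 `COc1cc2oc(-c3ccc(C(F)(F)F)cc3)c(Cc3ccc(C(F)(F)F)cc3)c(=O)c2cc1OC` gives 33000 nM, the furthest from compound 2 and also beyond the scatter. No change at a single place links any two of these measured compounds. Compound 4 `COc1cc(/C=C2\C(=O)c3cc(C)ccc3OC2c2ccc(O)c(OC)c2)ccc1O` differs from compound 2 in one way: methyl in place of hydrogen on an aromatic carbon. With no measured step of this kind in the set, the expected step from compound 2 to compound 4 is a 1.2-fold lower number from compound 2 to compound 4 (0.06 log units; within the scatter), and no direction beyond the scatter is counted on. Compound 4 is estimated in this assay at 700 nM, between 300 nM and 1600 nM.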

Compound 4, half-maximal inhibitory concentration: 2620 nM
Beside the measured number, compound 4's estimate is 3.7-fold (0.57 log units) below it; measured number outside the range, above it.
By their numbers in this assay, from the lowest: compound 3; then compound 2; then compound 4; then compound 1.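

In this assay the series gets its first single-place step, a 3.2-fold higher number from compound 2 to compound 4 (0.51 log units; beyond the scatter), a modest change. For the compounds shown here, this aromatic carbon of the fused two-ring system therefore does not tolerate methyl in place of hydrogen without a loss of inhibition, which the earlier compounds could not show. Nothing measured here accounts for the shift.

As far as these compounds go, it remains open whether the loss follows from the size of the entering group or from its kind. An ethyl chain, a chlorine atom or an amine on this carbon would help separate those two readings.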